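The source may report more compounds than this note shows. Statements on the series, on what has been measured and on what is new or still open speak of the compounds shown alone.

Measured so far:
- compound 1, `CN(/N=N/c1ccc(Br)cc1)C(=O)CCCCc1ccc(O)cc1`: 162 h
- compound 2, `CC(=O)c1ccc(/N=N/N(C)C(=O)CCCCc2ccc(O)cc2)cc1`: 32.7 h
- compound 3, `Cc1ccc(/N=N/N(C)C(=O)CCCCc2ccc(O)cc2)cc1`: 79.7 h

In an ADME assay on a cell-free system (plasma, Homo sapiens) for metabolic stability, read by HPLC (on this read-out higher numbers stand for a longer-lived compound and lower numbers for a shorter-lived compound), compound 3 stands second of the three, above compound 2 and below compound 1, with a 2.0-fold lower number from compound 1 to compound 3 (0.31 log units; beyond the scatter) and a 2.4-fold higher number from compound 2 to compound 3 (0.39 log units; beyond the scatter) setting it apart from both neighbours.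

Compound 4, `CN(/N=N/c1ccc(C#N)cc1)C(=O)CCCCc1ccc(O)cc1`, differs from compound 3 only at one place on the ring: cyano in place of methyl on an aromatic carbon

For the measured compounds named here, the steps that bear on this change are the ones at the same position. Swapping methyl for bromo gave a 2.0-fold lower number from compound 1 to compound 3 (0.31 log units; beyond the scatter), and swapping methyl for acetyl, run backwards, would undo a 2.4-fold higher number from compound 2 to compound 3 (0.39 log units; beyond the scatter). The cyano group, like acetyl, brings one hydrogen-bond acceptor to the same aromatic carbon, so the expected step resembles the reverse of the acetyl case: a modest drop in this assay, beyond the scatter but not large. Compound 4 is therefore expected to show a 2.0-fold lower number from compound 3 to compound 4 (0.30 log units; within the scatter), landing at an estimated 40 h, within a likely range from 16 h to 100 h.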

Compound 4, half-life: 11.8 h
The estimate for compound 4 lay 3.4-fold (0.53 log units) above the measured number; measured number outside the range, below it.
By their numbers in this assay, from the lowest: compound 4; then compound 2; then compound 3; then compound 1.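

In this assay cyano at this aromatic carbon gives the lowest number of the four compounds, with a 6.8-fold lower number from compound 3 to compound 4 (0.83 log units; beyond the scatter) and a 2.8-fold lower number from compound 2 to compound 4 (0.44 log units; beyond the scatter) and, as the widest gap, a 14-fold lower number from compound 1 to compound 4 (1.14 log units; beyond the scatter) on the shared core. Bromo, methyl and acetyl alone showed only part of the range this position can cover. Replacing the single heavy atom of methyl with the two heavy atoms of cyano is a small change by atom count, yet it moves the half-life well beyond the scatter.

On these data alone, whether an amine, a carboxylic acid or a methoxy group at this carbon would land near cyano or near bromo remains open, as does whether the same order would hold with a longer chain on the shared core. Nothing available here explains the order of these four groups.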